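The compounds below may be only part of what the source reports. "The series", "measured", "known", "first", "only" and "open" are said of these compounds alone.

Three related compounds already have numbers in a functional assay on B16-F10 cells (Mus musculus) for antiproliferative activity, read by colorimetric assay and MTT assay, with a stated time of 48 h; a lower number here means a stronger inhibitor, a higher number a weaker inhibitor. There, compound 1 (`Cc1ccc(S(=O)(=O)NC(=O)c2cccnc2)cc1`) gives 18500 nM, compound 2 (`O=C(NS(=O)(=O)c1ccccc1)c1ccccn1`) gives 14200 nM, and compound 3 (`O=C(NS(=O)(=O)c1ccc(F)cc1)c1ccccn1`) gives 10900 nM. Compound 3 lies within the usual scatter of both other compounds, so these numbers do not rank it against either one.

The unmeasured compound 4 (`Cc1ccc(S(=O)(=O)NC(=O)c2ccccn2)cc1`) differs from compound 3 at a single place, with methyl in place of fluoro on an aromatic carbon. No direct swap of these two groups has been measured, so the evidence is indirect. The closest guide is the measured step of a 1.3-fold lower number from compound 2 to compound 3 (0.11 log units; within the scatter), which put fluoro in place of hydrogen on an aromatic carbon and stayed within the scatter. The methyl group of compound 4 also occurs, though on a core that differs, in compound 1, and the value of compound 1 of 18500 nM is of the same order as the others.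

On this evidence, no change beyond the scatter is expected in this assay, and no direction can be firmly predicted. The expected step is small, at a 1.2-fold higher number from compound 3 to compound 4 (0.09 log units; within the scatter). For compound 4 the estimated value is 13500 nM, with an expected range of 7500 nM to 24000 nM.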

Compound 4, half-maximal inhibitory concentration: 16700 nM
Compound 4: middle estimate off by 1.2-fold (0.09 log units), on the low side, and the stated range covers the measured number.
By their numbers in this assay, from the lowest: compounds 3, 2, 4 and 1 (each within the scatter of the next).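

In this assay, hydrogen, fluoro and methyl can now be compared at one place, on an aromatic carbon of a six-membered aromatic ring of carbon only, para to a large group. Methyl in place of fluoro gives a 1.5-fold higher number from compound 3 to compound 4 (0.19 log units; within the scatter), and methyl in place of hydrogen gives a 1.2-fold higher number from compound 2 to compound 4 (0.07 log units; within the scatter), so with the earlier fluoro step, a 1.3-fold lower number from compound 2 to compound 3 (0.11 log units; within the scatter), no pair of these three groups is separated beyond the scatter. The new compound also allows a direct reading of pyridin-2-yl in place of pyridin-3-yl on a carbonyl carbon, a 1.1-fold lower number from compound 1 to compound 4 (0.04 log units; within the scatter), a change that could not be isolated before and that also stays within the scatter, though nothing measured alongside these numbers offers any explanation for how closely they sit.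

The compounds shown carry only hydrogen, fluoro and methyl at this place, so it remains open whether an amine, a methoxy group or a longer chain there would move the number beyond the scatter. For the compounds shown here, the pyridin-2-yl and pyridin-3-yl comparison is also seen only with methyl, so whether it stays this small with fluoro or hydrogen remains open too.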